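Working notes: replacing the 4-nitrophenyl group of compound 2

The source may report more compounds than this note shows. Statements on the series, on what has been measured and on what is new or still open speak of the compounds shown alone.

Measured so far in a physicochemical assay for solubility, read by spectrophotometry, in phosphate buffer, with a stated time of 18 h, at pH 7.4; a lower number here means a less soluble compound, a higher number a more soluble compound:
- compound 1 `Cc1nn(-c2ccccc2)c2nc(-c3ccc(I)cc3)c(C#N)c(-c3ccccc3O)c12` gives 1500 nM here
- compound 2 `Cc1nn(-c2ccccc2)c2nc(-c3ccc([N+](=O)[O-])cc3)c(C#N)c(-c3ccccc3O)c12` gives 6000 nM here

Among the measured compounds shown here, compound 2 holds the higher of these two numbers, and compound 1 is its only comparison. Compound 3 `Cc1nn(-c2ccccc2)c2nc(-c3ccc4c(c3)CCCC4)c(C#N)c(-c3ccccc3O)c12` has not yet been measured in this assay and keeps the shared core. The change is 1,2,3,4-tetrahydronaphthalen-6-yl in place of 4-nitrophenyl on an aromatic carbon, with 1,2,3,4-tetrahydronaphthalen-6-yl in place of 4-nitrophenyl on an aromatic carbon, ortho to a cyano group.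

For the measured compounds named here, only one measured step bears on this: a 4.0-fold higher number from compound 1 to compound 2 (0.60 log units; beyond the scatter), a modest change beyond the scatter, with nitro in place of iodo. The entering group appears in neither measured compound, so the read-across is loose. Like compound 1 at 1500 nM in this read-out, compound 3 has no nitro group, so a fall of similar modest size is expected. The expected step is a 4.0-fold lower number from compound 2 to compound 3 (0.60 log units; beyond the scatter) and it rests on that single comparison. Compound 3 is estimated at 1500 nM in this read-out, with 400 nM to 5000 nM as the expected range.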

Compound 3, solubility: 13000 nM
Estimate against measurement, compound 3: 8.7-fold (0.94 log units) below; measured number outside the range, above it.
By their numbers in this assay, from the lowest: compound 1; then compound 2; then compound 3.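

In this assay, the step of a 2.2-fold higher number from compound 2 to compound 3 (0.34 log units; beyond the scatter) shows that losing the nitro group at this position, on an aromatic carbon ortho to a cyano group, does not by itself bring the number down towards that of compound 1; here, 1,2,3,4-tetrahydronaphthalen-6-yl, an all-carbon group with no hydrogen-bond acceptors, gives the highest number of the three. The step of an 8.7-fold higher number from compound 1 to compound 3 (0.94 log units; beyond the scatter) sets the two compounds without a nitro group at opposite ends of the order, with the nitro compound 2 between them, so the presence of nitro does not sort these three compounds. The data hold no measurement that explains this order, and the change of group cannot be tied to any one feature of it.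

The compounds shown leave open whether the fused saturated ring matters or whether an open chain, such as 4-butylphenyl, would give a similar number. They also leave open where a phenyl ring carrying an amine or a carboxylic acid would fall in this order on the shared core.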